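The source may report more compounds than this note shows. Statements on the series, on what has been measured and on what is new or still open speak of the compounds shown alone.

Compound 1 `CCN1CCN(Cc2ccc(NC(=O)c3ccc(C)c(C#Cc4cccnc4)c3)cc2C(F)(F)F)CC1` and compound 2 `CCN1CCN(Cc2ccc(NC(=O)c3ccc(C)c(C#Cc4ccc(NC(C)=O)nc4)c3)cc2C(F)(F)F)CC1` share one core and differ in a single group. In a functional assay on BaF3 cells (Mus musculus) for antiproliferative activity (a lower number here means that less compound is needed, a higher number that more compound is needed for the effect), compound 1 gives 1590 nM, and compound 2 gives 2050 nM. The step of a 1.3-fold higher number from compound 1 to compound 2 (0.11 log units; within the scatter) stays within the scatter, so on the numbers shown compound 2 stands level with compound 1 rather than apart from it.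

Compound 3 `CCN1CCN(Cc2ccc(NC(=O)c3ccc(C)c(C#Cc4ccc(NC(=O)C5CC5)nc4)c3)cc2C(F)(F)F)CC1` has not yet been measured in this assay. It differs from compound 2 in one place: cyclopropyl in place of methyl on a carbonyl carbon. For the measured compounds named here, no measured step swaps a methyl for a cyclopropyl on a carbonyl carbon, so the only guidance comes from the step of a 1.3-fold higher number from compound 1 to compound 2 (0.11 log units; within the scatter), which shows that adding the acetamido group itself moved the number very little. A change confined to the outer end of that same group is therefore expected to give no step beyond the scatter. For compound 3 the expected step is a 1.1-fold lower number from compound 2 to compound 3 (0.06 log units; within the scatter). Compound 3 is estimated at 1800 nM, most likely falling between 800 nM and 4000 nM.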

Compound 3, half-maximal effective concentration: 1800 nM
For compound 3 middle estimate and measured number coincide at the digits printed, within the range that was stated.
By their numbers in this assay, from the lowest: compounds 1, 3 and 2 (each within the scatter of the next).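

In this assay, for the compounds shown here, the step of a 1.1-fold lower number from compound 2 to compound 3 (0.06 log units; within the scatter) gives the first reading at the outer end of the amide: cyclopropyl, with its three-membered ring and 3 heavy atoms, replaces methyl, with 1 heavy atom, on a carbonyl carbon without a step beyond the scatter. Compared with hydrogen on the aromatic carbon, the complete (cyclopropylcarbonyl)amino group gives a 1.1-fold higher number from compound 1 to compound 3 (0.05 log units; within the scatter) and so also stays level, which means that two different amides now read the same as the compound carrying neither, not just the acetamido group of the earlier comparison. No measured evidence is available to explain why these numbers stay level.

The compounds shown leave open whether a larger group on the carbonyl carbon, such as a longer chain like pentyl or a cyclohexyl ring, would give a step beyond the scatter. They also leave open whether replacing the whole amide on the aromatic carbon with a free amine or a carboxylic acid would do so, since every group compared here at that place is either hydrogen or an amide.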